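This account rests on a few compounds, and the source may have more. Where it says the series, first, only, none or still open, it means among the compounds named here.

Measured so far:

Compound 1, `O=C(Nc1ccccc1C(F)(F)F)C1CCc2ccccc2N1C(=O)c1ccccc1`: 6500 nM
Compound 2, `O=C(Nc1cc(C(F)(F)F)cc(C(F)(F)F)c1)C1CCc2ccccc2N1C(=O)c1ccc(Cl)cc1`: 2220 nM
Compound 3, `O=C(Nc1ccccc1O)C1CCc2ccccc2N1`: 5610 nM

All three share a core and were tested in a functional assay on HCT-15 cells (Homo sapiens) for cytotoxicity, read by sulforhodamine B assay, with a stated time of 72 h; a lower number here means a stronger inhibitor of growth, a higher number a weaker inhibitor of growth. Among these three numbers compound 2 stands lowest, and its gap to each of the other two is beyond the usual scatter: compound 3 sits a little higher, compound 1 higher still. Compound 2 is thus the strongest inhibitor of growth of the three on the numbers shown, although none of the three is potent in absolute terms.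

The next compound, compound 4, `CCCC(=O)N1c2ccccc2CCC1C(=O)Nc1cc(C(F)(F)F)cc(C(F)(F)F)c1`, has not yet been measured in this assay. It keeps everything of compound 2 except one group on the carbonyl carbon attached to the ring nitrogen: propyl in place of 4-chlorophenyl on a carbonyl carbon. The 4-chlorophenyl that leaves is a ring; the propyl that enters is a short chain.

Among the measured compounds shown here, no pair among the measured compounds shows what this kind of exchange does here, so the direction can only be guessed. The expectation is a modest step from compound 2 to compound 4, a 1.6-fold higher number from compound 2 to compound 4 (0.20 log units; within the scatter), most likely toward a somewhat higher number, but possibly no change beyond the scatter. On that basis compound 4 is estimated at 3500 nM, with a plausible range from 1500 nM to 9000 nM.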

Compound 4, concentration for 50% growth inhibition: 21900 nM
The estimate for compound 4 lay 6.3-fold (0.80 log units) below the measured number, and the stated range ends below it.
By their numbers in this assay, from the lowest: compound 2; then compounds 3 and 1 (each within the scatter of the next); then compound 4.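

In this assay, the group on the carbonyl carbon whose other neighbour is the amide-type nitrogen in a ring proves to matter: with the rest of the molecule unchanged, propyl in place of 4-chlorophenyl gives a 9.9-fold higher number from compound 2 to compound 4 (0.99 log units; beyond the scatter). The earlier compounds shown here all differed in more than one place, so they could not show this; the new pair isolates this position and links the 4-chlorophenyl to stronger inhibition of growth than the short chain, leaving compound 4 with the highest number of the four. Nothing measured here accounts for the size of this change.

This single pair cannot say whether the ring, the chlorine or simply the larger group counts, and a plain phenyl, a cyclohexyl or a longer chain such as hexyl on the same carbonyl, with the rest of compound 2 kept, would begin to separate these readings. Going by these compounds, it also remains open whether the same exchange has a similar effect when the trifluoromethyl groups on the other side of the molecule are replaced.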